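This account rests on a few compounds, and the source may have more. Where it says the series, first, only, none or still open, it means among the compounds named here.

Measured so far in an assay on cells for inhibition of steroid 17-alpha-hydroxylase/17,20 lyase (Homo sapiens), read by scintillation counting, with stated times of 60 min and 4 h; a higher number here means a weaker inhibitor, a lower number a stronger inhibitor: compound 1 `O=S(=O)(C(F)F)N1CCN(c2ccc(/C=C/c3cc(F)cc(Cn4ccnc4)c3)cc2)CC1` gives 5 nM; compound 2 `O=S(=O)(C1CC1)N1CCN(c2ccc(/C=C/c3cc(F)cc(Cn4ccnc4)c3)cc2)CC1` gives 34 nM; compound 3 `N#CCS(=O)(=O)N1CCN(c2ccc(/C=C/c3cc(Cl)cc(-c4ccncc4)c3)cc2)CC1` gives 6 nM.

Compound 3 stands second highest of the three numbers: its nearest neighbour is compound 1, within the scatter, and compound 2 is furthest, beyond the scatter. Compound 4 `O=S(=O)(C(F)F)N1CCN(c2ccc(/C=C/c3cc(Cl)cc(-c4ccncc4)c3)cc2)CC1` differs from compound 3 in one place: difluoromethyl in place of cyanomethyl on a sulfonyl sulfur, that is, (cyanomethyl)sulfonyl to (difluoromethyl)sulfonyl. Going by the values given here, the only measured step at this sulfonyl sulfur is a 6.8-fold higher number from compound 1 to compound 2 (0.83 log units; beyond the scatter), which exchanges difluoromethyl for cyclopropyl rather than for cyanomethyl, so no step bears directly on the change. Compound 1, which carries the entering difluoromethyl on a different core, sits within the scatter of compound 3. Compound 4 is therefore expected to show no step beyond the scatter, a 1.2-fold lower number from compound 3 to compound 4 (0.08 log units; within the scatter), with an estimate of 5 nM (range 2 nM to 15 nM).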

Compound 4, half-maximal inhibitory concentration: 5 nM
Beside the measured number, compound 4's estimate shows no gap at the digits printed; measured number inside the range.
By their numbers in this assay, from the lowest: compounds 1, 4 and 3 (each within the scatter of the next); then compound 2.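

In this assay difluoromethyl in place of cyanomethyl on a sulfonyl sulfur gives a 1.2-fold lower number from compound 3 to compound 4 (0.08 log units; within the scatter). This is a direct comparison of the two groups on the core of compound 3, and it does not separate them, even though the nitrile is lost in the exchange. Nothing measured here explains this result.

As far as these compounds go, whether the change seen in a 6.8-fold higher number from compound 1 to compound 2 (0.83 log units; beyond the scatter) carries over to the core of compound 3 remains open. So does how a longer chain or an amine on the sulfonyl sulfur would read on either core.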